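A few compounds are considered here, and "the series" means these few. Any claim that something is new, unique, unknown or untested is made for them only; others in the source may bear on it.

In an ADME assay on NIH3T3 cells (Mus musculus) for cytotoxicity, read by MTT assay, with a stated time of 24 h (a lower number here means a stronger inhibitor, a higher number a weaker inhibitor), compound 1 `O=C(CSc1nnc(-c2ccncc2)o1)N/N=C/c1cccc(F)c1` reads 205000 nM and compound 2 `O=C(CSc1nnc(-c2ccncc2)o1)N/N=C/c1ccccc1[N+](=O)[O-]` reads 214000 nM on the same scale. Compound 3 `O=C(CSc1nnc(-c2ccncc2)o1)N/N=C/c1ccccc1O` reads 155000 nM and so stands level with both, within the scatter. The change to compound 4 `O=C(CSc1nnc(-c2ccncc2)o1)N/N=C/c1ccc(Cl)cc1Cl` is 2,4-dichlorophenyl in place of 2-hydroxyphenyl on a carbon with a double bond to nitrogen and amounts to 2,4-dichlorophenyl in place of 2-hydroxyphenyl on a carbon with a double bond to nitrogen. Among the compounds with values here, three measured steps bear on it: a 1.0-fold higher number from compound 1 to compound 2 (0.02 log units; within the scatter) and a 1.3-fold lower number from compound 1 to compound 3 (0.12 log units; within the scatter) and a 1.4-fold lower number from compound 2 to compound 3 (0.14 log units; within the scatter) all stay small. No 2,4-dichlorophenyl compound has been measured yet. No step beyond the scatter is therefore expected in this assay in either direction. The expected move is a 1.2-fold higher number from compound 3 to compound 4 (0.06 log units; within the scatter) and remains small. Compound 4 is estimated at 180000 nM with an expected range from 105000 nM to 300000 nM in this measurement.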

Compound 4, half-maximal inhibitory concentration: 221000 nM
For compound 4 the middle estimate is 1.2-fold (0.09 log units) below the measured one, within the range that was stated.
By their numbers in this assay, from the lowest: compounds 3, 1, 2 and 4 (each within the scatter of the next).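

In this assay the 2,4-dichlorophenyl group on a carbon with a double bond to nitrogen, which has neither hydrogen-bond donor nor acceptor, reads level with the 2-hydroxyphenyl group of compound 3 (a 1.4-fold higher number from compound 3 to compound 4 (0.15 log units; within the scatter)). It also stays level with the 2-nitrophenyl group (a 1.0-fold higher number from compound 2 to compound 4 (0.01 log units; within the scatter)) and the 3-fluorophenyl group (a 1.1-fold higher number from compound 1 to compound 4 (0.03 log units; within the scatter)). All four aryl groups thus sit within the scatter at this position, and no evidence on a cause is available.
Going by these compounds, whether an amine, a carboxylic acid or a longer chain at this carbon would shift the reading remains open.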